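A few compounds are considered here, and "the series" means these few. Any claim that something is new, unique, unknown or untested is made for them only; others in the source may bear on it.

In a toxicity assay on L02 cells (Homo sapiens) for cytotoxicity, read by MTT assay, with a stated time of 72 h (a higher number here means a weaker inhibitor, a lower number a stronger inhibitor), compound 3 (`CN(C)CCCCn1c2c(c3ccccc31)C(=O)c1c[n+]([O-])c3ccccc3c1C2=O`) gives 300 nM and compound 2 (`CN1CCN(CCCn2c3c(c4ccccc42)C(=O)c2c[n+]([O-])c4ccccc4c2C3=O)CC1`) gives 230 nM, so the two stand within the scatter of each other. Compound 1 (`CCCN1CCN(CCCCn2c3c(c4ccccc42)C(=O)c2c[n+]([O-])c4ccccc4c2C3=O)CC1`) gives 6830 nM, well apart from both.

The next structure is compound 4 (`O=C1c2c[n+]([O-])c3ccccc3c2C(=O)c2c1c1ccccc1n2Cc1cn(C[C@@H](O)CO)nn1`). The change, on a saturated chain carbon bound to an aromatic nitrogen, is 1-(2,3-dihydroxypropyl)-1H-1,2,3-triazol-4-yl in place of 3-(dimethylamino)propyl on a saturated chain carbon bound to an aromatic nitrogen. Among the measured compounds shown here, no measured compound carries a 1-(2,3-dihydroxypropyl)-1H-1,2,3-triazol-4-yl group, so no measured step covers this change directly.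

The nearest guides are other side-chain changes. These are a 23-fold lower number from compound 1 to compound 3 (1.36 log units; beyond the scatter) and a 30-fold lower number from compound 1 to compound 2 (1.47 log units; beyond the scatter), both large, against a 1.3-fold higher number from compound 2 to compound 3 (0.12 log units; within the scatter), which is within the scatter. Side-chain changes in this series can therefore either leave the number in place or move it widely.

With a replacement this extensive, a step beyond the scatter towards a higher number is expected, though the direction is uncertain. The expected move is a 5.0-fold higher number from compound 3 to compound 4 (0.70 log units; beyond the scatter). For compound 4 the estimated value is 1500 nM, with an expected range of 300 nM to 8000 nM.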

Compound 4, half-maximal inhibitory concentration: 490 nM
The estimate for compound 4 lay 3.1-fold (0.49 log units) above the measured number; low and high end bracket the measured number.
By their numbers in this assay, from the lowest: compounds 2, 3 and 4 (each within the scatter of the next, the first and the last beyond it); then compound 1.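

In this assay the side chain on a saturated chain carbon bound to an aromatic nitrogen can lose its dimethylamino group and gain a triazole and two hydroxyl groups with little consequence: a 1.6-fold higher number from compound 3 to compound 4 (0.21 log units; within the scatter) stands as the step. Against the piperazine compounds, a 2.1-fold higher number from compound 2 to compound 4 (0.33 log units; beyond the scatter) is a modest step and a 14-fold lower number from compound 1 to compound 4 (1.14 log units; beyond the scatter) is a large one, so an amine in the side chain is not needed for a number near those of compound 2 and compound 3, and compound 1, which carries one, remains apart. No measurement at hand explains this result.

Still open, on these data alone, is whether the triazole or the 2,3-dihydroxypropyl part accounts for compound 4, which a simple methyl group or a carboxylic acid in place of that part would test. As far as these compounds go, the other configuration of the stereocentre in compound 4 also remains open.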